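The compounds below may be only part of what the source reports. "The series", "measured", "known", "first", "only" and "open" are said of these compounds alone.

The measured compounds:
- compound 1, `Cc1ccc(NC(=O)N[C@@H](C)c2ccccc2)cc1`: in an ADME assay on the whole organism with Oryza sativa as the target, tested at 1 uM (a higher number here means a weaker effect of the compound at the concentration tested, a lower number a stronger effect), compound 1 gives 99%.
- compound 2, `CCCCCCc1ccc(NC(=O)N[C@@H](C)c2ccccc2)cc1`: in this assay compound 2 gives 100%.
- compound 3, `CC(=O)c1ccc(NC(=O)N[C@@H](C)c2ccccc2)cc1`: in this assay compound 3 gives 99%.

Going by the values given here, all three share one core, a urea joining a substituted aromatic ring to a chiral phenylethyl group, and differ only in the single group carried on that aromatic ring. Compound 3 stands level with compound 1 at the digits shown, and the remaining step is a number 1 percentage points lower from compound 2 to compound 3 (within the scatter), so the three numbers sit together within the usual scatter of this kind of measurement.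

Compound 4, `C[C@H](NC(=O)Nc1ccc(F)cc1)c1ccccc1`, has not yet been measured. Its difference from compound 3 is fluoro in place of acetyl on an aromatic carbon. This is the same kind of change as the two that have already been followed, a swap of the group on the aromatic ring: no change at the digits printed from compound 1 to compound 3 (within the scatter) and a number 1 percentage points lower from compound 2 to compound 3 (within the scatter). Neither of those moved the read-out beyond the scatter, even when the group changed from a short chain to a long one or to a carbonyl-bearing group.

On that basis the step of no change at the digits printed from compound 3 to compound 4 (within the scatter) is expected to lie within the scatter, with no clear direction. For compound 4 the estimate in this assay is 99%, within a range from 93% to 100%.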

Compound 4, a percentage reported as activity, at one concentration (the size of the read-out at that concentration, not a potency): 97%
Compound 4: the middle estimate sits 2 percentage points above what was measured; the measured number falls inside the stated range.
By their numbers in this assay, from the lowest: compounds 4, 1, 3 and 2 (each within the scatter of the next).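

Replacing the acetyl, with its 3 heavy atoms and its double bond, by fluoro, a single fluorine atom, on the aromatic carbon para to a large group gives in this assay a number 2 percentage points lower from compound 3 to compound 4 (within the scatter). Fluoro is the only halogen among these compounds, and its comparisons with the other two groups read the same way, a number 3 percentage points lower from compound 2 to compound 4 (within the scatter) and a number 2 percentage points lower from compound 1 to compound 4 (within the scatter), so at this place a group as small as one atom and one as long as hexyl give numbers that cannot be told apart in this assay. No separate measurement is available that could explain these numbers or show what lies behind them.

The four compounds leave open whether any group on this aromatic carbon, such as an amine, a carboxylic acid or a nitrile, can move the read-out beyond the scatter at all. They also leave open whether a change elsewhere in the shared core, for example on the phenylethyl side or at the urea, would have a larger effect than these swaps on the ring have had.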